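Swapping chloro for methyl on the aryl ring of compound 2

A few compounds are considered here, and "the series" means these few. Any claim that something is new, unique, unknown or untested is made for them only; others in the source may bear on it.

Compound 2 `Nc1cc(-c2ccc(Cl)cc2)nc2cc(-c3ccccc3)nn12` is examined in a functional assay on the whole organism (strain Wistar) for inhibition, with Rattus norvegicus as the target, read by paw edema, with stated times of 30 min and 4 h, at a dose of 50 mg/kg by the oral route (a lower number here means less inhibition, a higher number more inhibition at the dose given (going by the name of the read-out)), where compound 2 gives 51.2%. Of the two measured compounds it stands lowest; compound 1 `Cc1ccc(-c2cc3nc(-c4ccc(F)cc4)cc(N)n3n2)cc1` gives 64.3% in this assay, a higher number that lies beyond the scatter. Compound 3 `Cc1ccc(-c2cc(N)n3nc(-c4ccccc4)cc3n2)cc1` has not been measured in this assay. It differs from compound 2 by methyl in place of chloro on an aromatic carbon. Going by the values given here, with no measured pair showing this change, the step is expected to be modest and upward in this assay, a number 4.8 percentage points higher from compound 2 to compound 3 (within the scatter), an estimate only. Compound 3 is accordingly expected to give about 56% in this assay, within a range from 42% to 70%.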

Compound 3, a percentage reported as inhibition, in the whole organism at one dose (the size of the read-out at that dose, not a potency): 54.8%
Compound 3: middle estimate off by 1.2 percentage points, on the high side; the measured number falls inside the stated range.
By their numbers in this assay, from the lowest: compounds 2, 3 and 1 (each within the scatter of the next, the first and the last beyond it).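

Going by these compounds alone, this pair is the first direct reading of this position: in this assay, 4-methylphenyl in place of 4-chlorophenyl gives a number 3.6 percentage points higher from compound 2 to compound 3 (within the scatter). At this place on the ring, methyl and chloro therefore cannot be told apart by this read-out. Nothing available explains this result.

Still open, as far as these compounds go, is whether an amine, a carboxylic acid or a longer chain at this same place would give a step beyond the scatter. From the compounds shown here alone, whether methyl in place of chloro reads the same way on other aryl rings of the shared core is also open.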